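Diarylurea series: the step from compound 1 to compound 3

This account rests on a few compounds, and the source may have more. Where it says the series, first, only, none or still open, it means among the compounds named here.

Compound 1 `COc1cc(NC(=O)Nc2cc(Nc3ccc(C)c(C)c3)ncn2)cc(OC)c1` and compound 2 `CC(C)(C)c1ccc(Nc2cc(NC(=O)Nc3c(Cl)cccc3Cl)ncn2)cc1` have both been run in a functional assay on NCI-H226 cells (Homo sapiens) for inhibition, read by MTT assay, with a stated time of 48 h, tested at 10 uM; a higher number here means more inhibition at the concentration tested (going by the name of the read-out), a lower number less inhibition. In this assay compound 1 gives 45.3%, and compound 2 gives 40%; the two numbers lie within the scatter of each other, so neither compound is set apart. Compound 3 `COc1cc(NC(=O)Nc2cc(Nc3ccc(OC)c(I)c3)ncn2)cc(OC)c1` keeps the shared core of compound 1 and differs in one place: 3-iodo-4-methoxyphenyl in place of 3,4-dimethylphenyl on a nitrogen on an aromatic ring. For the measured compounds named here, no measured pair carries this change, so its size cannot be read from the series. Compound 3 is expected to show a step of a number 0.3 percentage points lower from compound 1 to compound 3 (within the scatter), within the scatter. Compound 3 is estimated at 45%, in a range from 25% to 65%.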

Compound 3, a percentage reported as inhibition, at one concentration (the size of the read-out at that concentration, not a potency): 40.1%
Compound 3: the middle estimate sits 4.9 percentage points above what was measured, within the range that was stated.
By their numbers in this assay, from the lowest: compounds 2, 3 and 1 (each within the scatter of the next).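

In this assay, 3-iodo-4-methoxyphenyl in place of 3,4-dimethylphenyl on the nitrogen gives a number 5.2 percentage points lower from compound 1 to compound 3 (within the scatter). This position therefore accepts an iodine and a methoxy group, with one more hydrogen-bond acceptor in the entering group, without a step beyond the scatter. No independent measurement explains this result.

Going by these compounds, it remains open whether an amine or a carboxylic acid on this ring, or a longer chain in place of the methoxy group, would move the number beyond the scatter.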